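Hydroxamate series: trimming the side chain, solubility outlook

A few compounds are considered here, and "the series" means these few. Any claim that something is new, unique, unknown or untested is made for them only; others in the source may bear on it.

Measured so far:
compound 1 `CC(C)C(NC(=O)c1ccc(C#Cc2ccccc2)cc1)C(=O)NO`: 7000 nM
compound 2 `NC(=O)C[C@H](NC(=O)c1ccc(C#Cc2ccccc2)cc1)C(=O)NO`: 61000 nM

In a physicochemical assay for solubility (a higher number here means a more soluble compound, a lower number a less soluble compound), compound 1 gives 7000 nM, the lowest of the two numbers. Compound 2 gives 61000 nM, a gap beyond the scatter. Compound 3 `O=C(CNC(=O)c1ccc(C#Cc2ccccc2)cc1)NO` differs from compound 1 in one place: hydrogen in place of isopropyl on a saturated chain carbon bound to an amide-type nitrogen and a carbonyl carbon. No step between measured compounds covers this change, so the expectation rests on the pair shown alone. An increase beyond the scatter is expected because compound 2, which also lacks the isopropyl, gives 61000 nM. The expected step is a 3.6-fold higher number from compound 1 to compound 3 (0.55 log units; beyond the scatter). For compound 3 a value of 25000 nM is estimated, within 9000 nM to 70000 nM.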

Compound 3, solubility: 21000 nM
Compound 3: middle estimate off by 1.2-fold (0.08 log units), on the high side; low and high end bracket the measured number.
By their numbers in this assay, from the lowest: compound 1; then compound 3; then compound 2.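

In this assay, for the compounds shown here, hydrogen in place of isopropyl on a saturated chain carbon bound to an amide-type nitrogen and a carbonyl carbon gives a 3.0-fold higher number from compound 1 to compound 3 (0.48 log units; beyond the scatter) as the first direct step at this position. Hydrogen in place of carbamoylmethyl on that carbon gives a 2.9-fold lower number from compound 2 to compound 3 (0.46 log units; beyond the scatter) and so ranks the three groups, with hydrogen above isopropyl and below carbamoylmethyl, each gap beyond the scatter. Nothing on hand explains either step.

On these data alone, whether an amine, a carboxylic acid or a longer chain on this carbon would exceed carbamoylmethyl remains open. So does whether this order holds on another core.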